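Swapping Dichloro for Dimethoxy on the Benzylamine Arm

A few compounds are considered here, and "the series" means these few. Any claim that something is new, unique, unknown or untested is made for them only; others in the source may bear on it.

Measured so far:
compound 1 `Nc1cc(N)c2nc(-c3ccccc3)c(Oc3ccc(Cl)c(Cl)c3)nc2c1` gives 12000 nM in a functional assay on U-251 cells (Homo sapiens) for inhibition, read by sulforhodamine B assay, with a stated time of 48 h; a higher number here means a weaker inhibitor of growth, a lower number a stronger inhibitor of growth
compound 2 `CCOC(=O)[C@H](CCC(=O)O)NC(=O)c1ccc(CNc2nc3cc(N)cc(N)c3nc2-c2ccccc2)cc1` gives only a limit, < 100000 nM, in this assay
compound 3 `Nc1cc(N)c2nc(-c3ccccc3)c(NCc3ccc(Cl)c(Cl)c3)nc2c1` gives 2090 nM in this assay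

Of the two real numbers, compound 3 has the lower one; compound 1 lies higher by a gap beyond the scatter, so compound 3 is the stronger of that pair. Compound 4 `COc1ccc(CNc2nc3cc(N)cc(N)c3nc2-c2ccccc2)cc1OC` is not yet measured. It differs from compound 3 in one place: 3,4-dimethoxyphenyl in place of 3,4-dichlorophenyl on a saturated chain carbon bound to a nitrogen on an aromatic ring. Among the compounds with values here, no measured pair shows such a change, so the direction is uncertain; a modest move toward a higher number seems the likelier outcome, and the expected step is a 2.2-fold higher number from compound 3 to compound 4 (0.33 log units; beyond the scatter). For compound 4 the estimate is 4500 nM, within 1500 nM to 15000 nM.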

Compound 4, concentration for 50% growth inhibition: 17000 nM
Beside the measured number, compound 4's estimate is 3.8-fold (0.58 log units) below it, outside the stated range (above it).
By their numbers in this assay, from the lowest: compound 3; then compounds 1 and 4 (each within the scatter of the next).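

In this assay, the aryl group on a saturated chain carbon bound to a nitrogen on an aromatic ring proved to matter: 3,4-dimethoxyphenyl in place of 3,4-dichlorophenyl gave an 8.1-fold higher number from compound 3 to compound 4 (0.91 log units; beyond the scatter) in growth inhibition. Within the data shown here, the earlier compounds offered no pair differing in one place, so this is the only direct reading of this position, and it favours the dichloro group. Nothing measured here accounts for the size of this step.

Still open, from the compounds shown here alone, is whether a single chlorine or a single methoxy group would keep the number of compound 3. Also open, going by these compounds, is how an amine or a carboxylic acid on this ring would compare.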